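This account rests on a few compounds, and the source may have more. Where it says the series, first, only, none or still open, it means among the compounds named here.

Measured compounds:
compound 1 `O[C@@H]1[C@@H](c2cn(Cc3ccccc3)nn2)NC[C@@H]1O` — "not active" (no number reported)
compound 2 `O[C@@H]1[C@H](O)CN[C@@H]1Cn1cc(-c2ccccc2)nn1` — <= 50%
compound 3 `O[C@@H]1[C@H](O)CN[C@@H]1c1cn(Cc2ccccc2)nn1` — "not active" (no number reported)

In an assay on isolated protein for inhibition of alpha-galactosidase (Coffea arabica), with stated times of 5 min and 20 min, tested at 1 mM (on this read-out lower numbers stand for less inhibition and higher numbers for more inhibition at the one concentration tested (going by the name of the read-out)), compound 1 gives "not active" (no number reported). Compound 3 gives "not active" (no number reported). For compound 2 the read-out is a limit rather than a number, <= 50%, so compound 2 stands only as a bounded value, which is the limit of <= 50% in this assay, at which 1 of the 3 values shown sits. Compound 4 `O[C@H]1[C@@H](O)CN[C@@H]1Cn1cc(-c2ccccc2)nn1` has not yet been measured. Compared with compound 2, (the two compounds have the same atoms and bonds and differ only in configuration as drawn: 2 of 3 stereo elements differ; a stereocentre at a saturated ring carbon is drawn S in compound 2 and R in compound 4; a stereocentre at a saturated ring carbon is drawn R in compound 2 and S in compound 4). Among the compounds with values here, no step between two measured compounds is known here. Still, the fact that compounds 1 and 3 differ only in the configuration as drawn shows two compounds that are both reported as not active, so a change of configuration alone is expected to move this assay by no more than the scatter, in no particular direction. Compound 4 is therefore expected to give 20% (range 0% to 50%), an expected step that the limit leaves unreadable from compound 2 to compound 4.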

Compound 4, a percentage reported as inhibition, at one concentration (the size of the read-out at that concentration, not a potency): "not active" (no number reported)
The entry for compound 4 holds no number; the estimate stays without a comparison.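

Within the data shown here, compound 2 stands only as a limit and compound 4 has no number, so no step between these two compounds can be read. The compounds shown leave open how far a change of configuration alone can shift the result in this assay.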